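The source may report more compounds than this note shows. Statements on the series, on what has been measured and on what is new or still open speak of the compounds shown alone.

Among the measured compounds shown here, compound 1 `CC(=O)Nc1cc(Oc2ccc(Nc3nccc4[nH]cc(-c5ccc(F)cc5)c(=O)c34)cc2F)ccn1` has the higher of the two measured numbers: in a functional assay on HT-29 cells (Homo sapiens) for antiproliferative activity, read by MTT assay, with a stated time of 72 h, tested at 10 uM (a lower number here means less inhibition, a higher number more inhibition at the concentration tested (going by the name of the read-out)), compound 1 gives 36.8%, the higher of the two numbers known so far. Compound 2 `CCCCC(=O)Nc1cc(Oc2ccc(Nc3nccc4[nH]cc(-c5ccc(F)cc5)c(=O)c34)cc2F)ccn1` gives -42.2% in this assay, and the change a number 79 percentage points lower from compound 1 to compound 2 (beyond the scatter) came with propyl in place of hydrogen on a saturated chain carbon bound to a carbonyl carbon. Compound 3 `O=C(CO)Nc1cc(Oc2ccc(Nc3nccc4[nH]cc(-c5ccc(F)cc5)c(=O)c34)cc2F)ccn1` differs from compound 1 by hydroxy in place of hydrogen on a saturated chain carbon bound to a carbonyl carbon. For the measured compounds named here, only that one measured step touches the same place, and it was large and downward; but it added a propyl chain, not a hydroxy group, so it carries over only loosely. A smaller downward step is therefore expected, a number 16.8 percentage points lower from compound 1 to compound 3 (beyond the scatter), with wide uncertainty. Compound 3 is estimated to give about 20% in this assay, expected to fall between -25% and 55%.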

Compound 3, a percentage reported as inhibition, at one concentration (the size of the read-out at that concentration, not a potency): 18.5%
Beside the measured number, compound 3's estimate is 1.5 percentage points above it, and the stated range covers the measured number.
By their numbers in this assay, from the lowest: compound 2; then compound 3; then compound 1.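

In this assay, hydroxy in place of hydrogen on a saturated chain carbon bound to a carbonyl carbon gave a number 18.3 percentage points lower from compound 1 to compound 3 (beyond the scatter), so an added group at this place need not bring a drop as large as the one seen with propyl. Exchanging one group for the other at the same place gave a number 60.7 percentage points higher from compound 2 to compound 3 (beyond the scatter), which shows that the result depends strongly on which group is added, although compound 1, with only hydrogen there, still gives the highest number of the three. Nothing available explains why these two groups differ so much.

From the compounds shown here alone, it remains open whether an amine or a methoxy group at this place would match compound 1 or exceed it. An ethyl group or a carboxylic acid could also show whether the steep fall belongs to propyl alone.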